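This account rests on a few compounds, and the source may have more. Where it says the series, first, only, none or still open, it means among the compounds named here.

Within the data shown here, in an ADME assay on MT4 cells (Homo sapiens) for cytotoxicity (on this read-out lower numbers stand for higher toxicity in this test and higher numbers for lower toxicity in this test), compound 1 `CC[C@H]1CC[C@H](c2ccc(NC(=S)Nc3cccc(C(F)(F)F)c3)cc2)CC1` gives 39000 nM and compound 2 `FC(F)(F)c1cccc(NC(=S)Nc2ccc(I)cc2)c1` gives 10000 nM, the lower of the two numbers so far. Compound 3 `FC(F)(F)c1cccc(NC(=S)Nc2ccc(Cl)cc2)c1` differs from compound 2 by chloro in place of iodo on an aromatic carbon. Among the measured compounds shown here, the only measured step at this place is a 3.9-fold lower number from compound 1 to compound 2 (0.59 log units; beyond the scatter), a modest change in which iodo replaced 4-ethylcyclohexyl, and no measured step compares chloro with iodo. No change beyond the scatter is therefore expected, and the estimated step is a 1.2-fold higher number from compound 2 to compound 3 (0.08 log units; within the scatter). In this assay the estimate for compound 3 is 12000 nM, with an expected range of 5000 nM to 30000 nM.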

Compound 3, half-maximal cytotoxic concentration: 6800 nM
Estimate against measurement, compound 3: 1.8-fold (0.25 log units) above; measured number inside the range.
By their numbers in this assay, from the lowest: compounds 3 and 2 (each within the scatter of the next); then compound 1.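

In this assay chloro in place of iodo on the aromatic carbon gives a 1.5-fold lower number from compound 2 to compound 3 (0.17 log units; within the scatter) and so the two halogens are not separated at this position. Chloro in place of 4-ethylcyclohexyl gives a 5.7-fold lower number from compound 1 to compound 3 (0.76 log units; beyond the scatter) and this shows that the gap from 4-ethylcyclohexyl is not specific to iodo. No measured evidence bears on the reason for these numbers. Open, as far as these compounds go, is how an amine, a methoxy group or a carboxylic acid would read at this position. Also open, from the compounds shown here alone, is whether the halogen result holds with a nitrile in place of trifluoromethyl.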